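Moving a Fluorinated Benzyl Group Across Two Related Cores

A few compounds are considered here, and "the series" means these few. Any claim that something is new, unique, unknown or untested is made for them only; others in the source may bear on it.

Compound 1 `Cn1nc(-c2nnc(SCc3ccc(C(F)(F)F)cc3)o2)cc1-c1ccc(C(F)(F)F)cc1` and compound 2 `Cn1nc(-c2nnc(SCCc3ccc(F)cc3)o2)cc1-c1ccc(C(F)(F)F)cc1` share one core; compound 3 `Cn1nc(-c2ccc(C(F)(F)F)cc2)cc1-c1nnc(SCc2ccc(C(F)(F)F)cc2)o1` and compound 4 `Cn1nc(-c2ccc(C(F)(F)F)cc2)cc1-c1nnc(SCCc2ccc(F)cc2)o1` share another, built from the same atoms as compound 1 but joined differently. The difference between the two cores is not broken down here. All four belong to a functional assay on MCF7 cells (Homo sapiens) for cytotoxicity, read by MTT assay, with a stated time of 24 h; on this read-out higher numbers stand for weaker inhibition and lower numbers for stronger inhibition.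

In this assay compound 1 gives 15500 nM and compound 2 gives 25200 nM. The change between them, (4-fluorobenzyl in place of 4-(trifluoromethyl)phenyl on a saturated chain carbon bound to a sulfur), made a step of a 1.6-fold higher number from compound 1 to compound 2 (0.21 log units; within the scatter). Compound 3 gives 27100 nM in this assay, a number close to both compound 1 and compound 2, so the two cores look much alike on this read-out.

Compound 4 carries the same change on the other core: 4-fluorobenzyl in place of 4-(trifluoromethyl)phenyl on a saturated chain carbon bound to a sulfur. Because the step of a 1.6-fold higher number from compound 1 to compound 2 (0.21 log units; within the scatter) stayed within the scatter, the same change is expected to do little on the second core as well. Compound 4 is therefore estimated at 40000 nM in this assay, which corresponds to an expected step of a 1.5-fold higher number from compound 3 to compound 4 (0.17 log units; within the scatter). For compound 4 the expected range runs from 20000 nM to 80000 nM. The ground for this expectation is thin: a single earlier instance of the change, and a pair of cores whose relationship is not dissected, so the true number could sit somewhat away from the estimate.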

Compound 4, half-maximal inhibitory concentration: 45400 nM
Beside the measured number, compound 4's estimate is 1.1-fold (0.05 log units) below it; measured number inside the range.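

In this assay, putting 4-fluorobenzyl in place of 4-(trifluoromethyl)phenyl on a saturated chain carbon bound to a sulfur gave a 1.7-fold higher number from compound 3 to compound 4 (0.22 log units; within the scatter), so on this second core the change again stayed small enough to be lost in the ordinary variation between repeat measurements. The change therefore behaved alike on the two cores, and in this small set its effect carried over from one to the other: the same change on two cores in this assay, a 1.6-fold higher number (0.21 log units; within the scatter) from compound 1 to compound 2 and a 1.7-fold higher number (0.22 log units; within the scatter) from compound 3 to compound 4, 1.0-fold (0.01 log units) apart, within the scatter of two such steps

This agreement is only a match between two small steps, so it does not show that the change has any real effect on the read-out, and two cores in one cell assay cannot establish a rule for the wider series or explain why the steps match.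

Still open, on these data alone, is whether a group of a different kind in the same place, such as an amine or a carboxylic acid, would move the number by more than the scatter. A step of that size would be a sterner test of transfer, since it would show whether a clear effect on one core also appears on the other.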